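This account rests on a few compounds, and the source may have more. Where it says the series, first, only, none or still open, it means among the compounds named here.

Among the measured compounds shown here, in an ADME assay on L02 cells (Homo sapiens) for cytotoxicity, read by MTT assay, with a stated time of 24 h (on this read-out lower numbers stand for stronger inhibition and higher numbers for weaker inhibition), compound 1 `COc1cc(/C=C2\CN(C)C/C(=C\c3ccc(F)cc3)C2=O)cc(OC)c1` gives 21900 nM and stands highest of the two numbers so far, while compound 2 `COc1cc(/C=C2\CN(C)C/C(=C\c3cccc([N+](=O)[O-])c3)C2=O)cc(OC)c1` gives 10800 nM as the only other measured value. Compound 3 `COc1cc(/C=C2\CN(C)C/C(=C\c3ccc(F)cc3)C2=O)cc(OC)c1OC` differs from compound 1 by one change (methoxy in place of hydrogen on an aromatic carbon) and keeps the rest. For the measured compounds named here, the single measured step (a 2.0-fold lower number from compound 1 to compound 2 (0.31 log units; beyond the scatter)) is modest and lies at a different place, so it bears only loosely, and no measured step covers this methoxy change. In this assay a small step toward a lower number is therefore expected, possibly none beyond the scatter. The expected step is a 1.3-fold lower number from compound 1 to compound 3 (0.11 log units; within the scatter) on this estimate. For compound 3 the estimated value is 17000 nM (expected range 7500 nM to 38000 nM).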

Compound 3, half-maximal inhibitory concentration: 10700 nM
Estimate against measurement, compound 3: 1.6-fold (0.20 log units) above, and the stated range covers the measured number.
By their numbers in this assay, from the lowest: compounds 3 and 2 (each within the scatter of the next); then compound 1.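

In this assay, the aromatic carbon ortho to two methoxy groups and para to a large group proves open to change: methoxy in place of hydrogen there gives a 2.0-fold lower number from compound 1 to compound 3 (0.31 log units; beyond the scatter), a modest step. The earlier compounds shown here showed a change only on the other aromatic ring. Nothing at hand explains this step.

Open, going by these compounds, is whether a hydroxyl group, an ethoxy group or an amine at this carbon would move the number the same way. Also open, on these data alone, is whether the methoxy step holds with 3-nitrophenyl in place of 4-fluorophenyl.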